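Indanyl in place of chlorophenyl: an untested glucagon receptor ligand

The source may hold more compounds than are shown below. What is called first, only, known or untested is meant among the compounds shown, and "the series" means these compounds.

Compound 1 `O=C(O)CCNC(=O)c1ccc(CN(c2ccc(Cl)cc2)c2nc(-c3ccc(C(F)(F)F)cc3)cs2)cc1`: 53 nM
Compound 2 `O=C(O)CCNC(=O)c1ccc(CC(c2ccc(Cl)cc2)c2nc(-c3ccc(OC(F)(F)F)cc3)cs2)cc1`: 25 nM
Compound 3 `O=C(O)CCNC(=O)c1ccc(CN(c2ccc(C(F)(F)F)cc2)c2nc(-c3ccc(Cl)cc3)cs2)cc1`: 93 nM

Of the compounds shown here, three built on a shared core have been tested in an in vitro assay on BHK cells for binding affinity to Glucagon receptor (Homo sapiens); on this read-out lower numbers stand for stronger inhibition and higher numbers for weaker inhibition. Among them, compound 1 stands second highest of the three numbers. Its nearest neighbour is compound 3, whose number lies within the usual scatter of repeated measurements, so the two cannot be told apart. Compound 2 lies beyond that scatter, with a lower number than compound 1.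

Compound 4 `O=C(O)CCNC(=O)c1ccc(CN(c2ccc3c(c2)CCC3)c2nc(-c3ccc(C(F)(F)F)cc3)cs2)cc1` has not yet been measured. It differs from compound 1 in a single place: 2,3-dihydro-1H-inden-5-yl in place of 4-chlorophenyl on a nitrogen on an aromatic ring. Among the measured compounds shown here, none of the measured pairs shows this particular exchange, so there is no precedent to lean on. In that situation the sensible expectation for this assay is a step of a 1.1-fold higher number from compound 1 to compound 4 (0.05 log units; within the scatter) that stays within the scatter, with no clear direction. Compound 4 is therefore expected to give about 60 nM in this assay, with a plausible range from 20 nM to 180 nM.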

Compound 4, half-maximal inhibitory concentration: 64 nM
For compound 4 the middle estimate is 1.1-fold (0.03 log units) below the measured one; low and high end bracket the measured number.
By their numbers in this assay, from the lowest: compound 2; then compounds 1, 4 and 3 (each within the scatter of the next).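

In this assay, 2,3-dihydro-1H-inden-5-yl in place of 4-chlorophenyl on a nitrogen on an aromatic ring gives a 1.2-fold higher number from compound 1 to compound 4 (0.08 log units; within the scatter), so the two compounds cannot be told apart. For this one pair, the chlorine can therefore be lost and a five-membered non-aromatic ring of carbon only added, taking the group from 7 heavy atoms to 9, without a difference that stands out from the scatter. Nothing in the available data accounts for this result.

On these data alone, it remains open how this position responds to a plain phenyl, or to a phenyl ring carrying an amine or a carboxylic acid. Also open, as far as these compounds go, is whether the same exchange would give a similar result on the core of compound 2.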